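The source may report more compounds than this note shows. Statements on the series, on what has been measured and on what is new or still open speak of the compounds shown alone.

Measured so far:
- Compound 1 `c1ccc(-c2ccc3c(NCCCNCc4ccco4)ccnc3c2)cc1`: 9.47
- Compound 2 `Cc1cc(C)cc(Cc2ccc3c(NCCCNCc4ccco4)ccnc3c2)c1`: 9.47

In a physicochemical assay for acid dissociation, compound 2 gives 9.47, level with compound 1 at the digits shown; the step of no change at the digits printed from compound 1 to compound 2 (within the scatter) lies within the scatter. Compound 3 `FC(F)(F)c1cccc(Cc2ccc3c(NCCCNCc4ccco4)ccnc3c2)c1` is the next member, differing from compound 2 by 3-(trifluoromethyl)phenyl in place of 3,5-dimethylphenyl on a saturated chain carbon bound to an aromatic carbon. Among the compounds with values here, the one measured step that bears on this change is no change at the digits printed from compound 1 to compound 2 (within the scatter), in which the distal aryl portion was altered while the rest of the shared core and its amine chain stayed the same, and the acid dissociation constant did not move beyond the scatter. The change from compound 2 to compound 3 again touches only that distal aryl portion, so no step beyond the scatter is expected in this assay, the estimated step being a number 0.02 log units lower from compound 2 to compound 3 (within the scatter). Compound 3 is therefore expected to give 9.45, with a range of 9.15 to 9.75.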

Compound 3, acid dissociation constant: 9.47
The estimate for compound 3 lay 0.02 log units below the measured number; measured number inside the range.
By their numbers in this assay, from the lowest: compounds 1, 2 and 3 (each within the scatter of the next).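

In this assay, putting 3-(trifluoromethyl)phenyl in place of 3,5-dimethylphenyl on a saturated chain carbon bound to an aromatic carbon gives no change at the digits printed from compound 2 to compound 3 (within the scatter). Compounds 1 and 2 had shown only that replacing phenyl on an aromatic carbon with 3,5-dimethylbenzyl leaves the number level; this step holds the saturated chain carbon in place and shows the same for an exchange of the aryl group on it, with fluorine entering the compound for the first time. Nothing at hand explains why the number holds across these changes.

The compounds shown leave open whether an amine or a carboxylic acid on that aryl ring would leave the number level as well. They also leave open what a longer chain in place of the saturated chain carbon would do.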